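This account rests on a few compounds, and the source may have more. Where it says the series, first, only, none or still open, it means among the compounds named here.

The series shares one core, seen in compound 1 `Cc1ccc(N2C(=O)C/C(=C\c3cccc(C(=O)Nc4cccc(F)c4)c3)C2=O)cc1`, compound 2 `COc1ccc(NC(=O)c2cccc(/C=C3\CC(=O)N(c4ccccc4)C3=O)c2)cc1` and compound 3 `COc1cc(NC(=O)c2cccc(/C=C3\CC(=O)N(c4ccccc4)C3=O)c2)cc(OC)c1OC`, which differ only in the substitution of their anilide rings. In an ADME assay on HCT-116 cells (Homo sapiens) for cytotoxicity, read by MTT assay, with a stated time of 72 h (a higher number here means a weaker inhibitor, a lower number a stronger inhibitor), compound 1 gives > 100000 nM, a limit of the assay rather than a number. In this assay compound 2 likewise reaches only > 100000 nM, again a limit. Compound 3 gives > 100000 nM, also a limit. Compound 2 therefore stands exactly where every measured member of the set stands, at the limit of > 100000 nM in this assay, at which 3 of the 3 values shown sit, and no numeric value separates it from compound 1 or compound 3.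

Compound 4 `O=C(Nc1ccc(Cl)cc1)c1cccc(/C=C2\CC(=O)N(c3ccccc3)C2=O)c1` is not yet measured. It differs from compound 2 in a single place: chloro in place of methoxy on an aromatic carbon, so that the (4-methoxyphenyl)amino group becomes a (4-chlorophenyl)amino group. Going by the values given here, no measured step bears on this change, and nothing in the set shows any substituent on that ring bringing the value off the limit. The expected step is a step that the limit leaves unreadable from compound 2 to compound 4, that is, nothing beyond the usual scatter. In this assay compound 4 is expected to give about 150000 nM, within a range of 50000 nM to 500000 nM, with a strong chance that only a limit is again reported.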

Compound 4, half-maximal inhibitory concentration: > 100000 nM
Compound 4: no number, only a limit (the forecaster's own chance of this, stated with the estimate: 85%); the middle value is on the limit's open side.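

In this assay compound 4 gives > 100000 nM, again a limit and not a number, so no step can be read between compound 2 and compound 4: the limit of > 100000 nM in this assay, at which 4 of the 4 values shown sit.

The compounds shown leave open whether any substituent on the anilide ring of the shared core yields a numeric value in this assay.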